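The source may hold more compounds than are shown below. What is called first, only, known or untested is meant among the compounds shown, and "the series" means these compounds.

Measured compounds in the series:

compound 1 `Cc1cccc(C)c1-c1cccc(COc2ccc(S(=O)(=O)CC(=O)O)cc2)c1` gives 66.1 nM
compound 2 `CCOc1cc(C)c(-c2cccc(COc3ccc(S(=O)(=O)CC(=O)O)cc3)c2)c(C)c1` gives 63.1 nM
compound 3 `O=C(O)CS(=O)(=O)c1ccc(OCc2cccc(-c3ccccc3Cl)c2)cc1` gives 28.8 nM

In a functional assay on CHO cells for agonist activity at Free fatty acid receptor 1 (Homo sapiens), read by FLIPR and calcium flux (a higher number here means that more compound is needed for the effect, a lower number that less compound is needed), compound 3 stands lowest of the three numbers. The step from compound 1 to compound 3 is a 2.3-fold lower number from compound 1 to compound 3 (0.36 log units; beyond the scatter), and the values of compound 2 and compound 3 differ by a comparable margin in the same direction.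

Compound 4 `CCOc1ccc(-c2cccc(COc3ccc(S(=O)(=O)CC(=O)O)cc3)c2)c(Cl)c1` is compound 3 with the change (ethoxy in place of hydrogen on an aromatic carbon). For the measured compounds named here, one measured step bears on this: ethoxy in place of hydrogen on the same aromatic ring, from compound 1 to compound 2, gave a 1.0-fold lower number from compound 1 to compound 2 (0.02 log units; within the scatter). Going by the values given here, that ring there carried two methyl groups rather than a chloro group, so the parallel is not exact, but it is the only guide available. On this basis no step beyond the scatter is expected in this assay.

Compound 4 is therefore estimated at 30 nM, with a range of 12 nM to 75 nM, which corresponds to an expected step of a 1.0-fold higher number from compound 3 to compound 4 (0.02 log units; within the scatter).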

Compound 4, half-maximal effective concentration: 51.3 nM
Beside the measured number, compound 4's estimate is 1.7-fold (0.23 log units) below it, and the stated range covers the measured number.
By their numbers in this assay, from the lowest: compounds 3, 4, 2 and 1 (each within the scatter of the next, the first and the last beyond it).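

With a chloro group in place of the two methyl groups, the same ethoxy change gives a 1.8-fold higher number from compound 3 to compound 4 (0.25 log units; within the scatter) in this assay and so stays without a step beyond the scatter on a second core. Against 2,6-dimethylphenyl, the 2-chloro-4-ethoxyphenyl group gives a 1.3-fold lower number from compound 1 to compound 4 (0.11 log units; within the scatter) and so does not keep the step beyond the scatter seen with 2-chlorophenyl alone. Ethoxy at this position, para to a large group, now reads alike on both cores: the same change on two cores in this assay, a 1.0-fold lower number (0.02 log units; within the scatter) from compound 1 to compound 2 and a 1.8-fold higher number (0.25 log units; within the scatter) from compound 3 to compound 4, 1.9-fold (0.27 log units) apart, within the scatter of two such steps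

Going by these compounds, whether a group other than ethoxy at this position, such as an amine, a carboxylic acid or a longer chain, would give a step beyond the scatter stays open. So does the effect of ethoxy on a ring with neither chloro nor methyl groups.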